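This account rests on a few compounds, and the source may have more. Where it says the series, first, only, none or still open, it means among the compounds named here.

Measured compounds:

Compound 1, `COC(=O)c1ccc(OCCCCOc2ccc(C(=O)CC3CCCC3)c(O)c2C)cc1`: compound 1 gives 12.2% in an assay on HEK293 cells for positive allosteric modulation of metabotropic glutamate receptor 2 (Rattus norvegicus), read by thallium flux, with a stated time of 2.5 min; a higher number here means a larger maximal response, a lower number a smaller maximal response.
Compound 2, `Cc1c(OCCCCOc2ccccc2C(=O)O)ccc(C(=O)CC2CCCC2)c1O`: compound 2 gives 98.8% in this assay.
Compound 3, `Cc1c(OCCCCOc2ccccc2C(=O)O)ccc(C(=O)CC(C)C)c1C`: compound 3 gives 76.2% in this assay.

Compound 2 and compound 1 share a core and differ in one place, (4-(methoxycarbonyl)phenyl in place of 2-carboxyphenyl on an oxygen on a saturated carbon). That change gave a number 86.6 percentage points lower from compound 2 to compound 1 (beyond the scatter). Compound 3 carries a different core from compound 2; how the two cores differ is not broken down here. In this assay compound 3 stands below compound 2 and well above compound 1.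

Compound 4, `COC(=O)c1ccc(OCCCCOc2ccc(C(=O)CC(C)C)c(C)c2C)cc1`, is not yet measured. It arises from compound 3 by 4-(methoxycarbonyl)phenyl in place of 2-carboxyphenyl on an oxygen on a saturated carbon, the same change, at the same place, that led from compound 2 to compound 1. On the strength of that step, compound 4 is expected to fall far below compound 3: the expected step is a number 64.2 percentage points lower from compound 3 to compound 4 (beyond the scatter). Because compound 3 starts from 76.2%, the drop is expected to be somewhat smaller in points than the earlier one, since the response cannot fall much below nothing. Compound 4 is therefore estimated at 12%, with a range from 0% to 35%.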

Compound 4, largest response reached (reported as percent of maximum), in percent of the reference or control that the assay uses: 15.9%
For compound 4 the middle estimate is 3.9 percentage points below the measured one, within the range that was stated.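

In this assay, 4-(methoxycarbonyl)phenyl in place of 2-carboxyphenyl on the oxygen again cost most of the response, giving a number 60.3 percentage points lower from compound 3 to compound 4 (beyond the scatter). The direction of the change therefore carried from one core to the other, and the step stayed large, but its size did not carry over unchanged: the same change on two cores in this assay, a number 86.6 percentage points lower (beyond the scatter) from compound 2 to compound 1 and a number 60.3 percentage points lower (beyond the scatter) from compound 3 to compound 4, 26.3 percentage points apart, beyond the scatter of two such steps. Two cores cannot show how large the fall would be on a third, and these compounds do not tie the gap between the steps to any single one of the ways the cores differ.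

The change replaces the acid with an ester and also moves the substituent on the ring, so these compounds leave open how much of the fall belongs to each of those two alterations. Also open, going by these compounds, is how the response would stand with another group in that place, such as a tetrazole or a primary amide on the phenyl ring.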